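This account rests on a few compounds, and the source may have more. Where it says the series, first, only, none or still open, it means among the compounds named here.

Compound 1 `Cc1cc(Nc2ccc(C(=O)/C=C/c3cccc(Br)n3)cc2)n2nc(SCc3ccc(F)cc3)nc2n1` gives 93.3% in a functional assay on MGC-803 cells (Homo sapiens) for inhibition, read by sulforhodamine B assay, with a stated time of 72 h, tested at 10 uM; a higher number here means more inhibition at the concentration tested (going by the name of the read-out), a lower number less inhibition.
Compound 2 `Cc1cc(Nc2ccc(C(=O)/C=C/c3cccc(Br)n3)cc2)n2nc(SCc3ccc(Br)cc3)nc2n1` gives 96.3%.
Compound 3 `Cc1cc(Nc2ccc(C(=O)/C=C/c3cccc(Br)n3)cc2)n2nc(SCc3ccc(C(F)(F)F)cc3)nc2n1` gives 96.6%.

Compound 3 has the highest of these three numbers, yet its steps to the other two lie within the scatter: a number 3.3 percentage points higher from compound 1 to compound 3 (within the scatter) and a number 0.3 percentage points higher from compound 2 to compound 3 (within the scatter). Compound 4 `Cc1cc(Nc2ccc(C(=O)/C=C/c3cccc(Br)n3)cc2)n2ncnc2n1` differs from compound 3 in one place: hydrogen in place of (4-(trifluoromethyl)benzyl)sulfanyl on an aromatic carbon. The measured steps, a number 3 percentage points higher from compound 1 to compound 2 (within the scatter) among them, all exchange one group for another within the arm that leaves here, and none removes the arm itself, so none bears directly on this change. Removing the whole arm is a larger change than any measured, so a decrease in this assay beyond the scatter is expected, though its size is uncertain. The expected step is a number 26.6 percentage points lower from compound 3 to compound 4 (beyond the scatter). Compound 4 is estimated at 70%, within 35% to 95%.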

Compound 4, a percentage reported as inhibition, at one concentration (the size of the read-out at that concentration, not a potency): 58.4%
Compound 4: the middle estimate sits 11.6 percentage points above what was measured; the range from low to high includes it.
By their numbers in this assay, from the lowest: compound 4; then compounds 1, 2 and 3 (each within the scatter of the next).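

Exchanging groups on the benzyl ring moved nothing beyond the scatter, but removing the whole arm does: in this assay the record shows a number 38.2 percentage points lower from compound 3 to compound 4 (beyond the scatter), a number 37.9 percentage points lower from compound 2 to compound 4 (beyond the scatter) and a number 34.9 percentage points lower from compound 1 to compound 4 (beyond the scatter). This position on the five-membered aromatic ring is therefore sensitive to losing the arm, although compound 4, with hydrogen there, still gives 58.4%. Nothing available explains this loss.

Going by these compounds, it remains open how much of the arm is needed: whether a methylsulfanyl group, a bare thiol or an amine at this carbon would keep the inhibition.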